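Notes on a methoxyphenyl swap from compound 2

The compounds below may be only part of what the source reports. "The series", "measured", "known", "first", "only" and "open" are said of these compounds alone.

In a functional assay on HeLa cells (Homo sapiens) for inhibition, with a stated time of 48 h, tested at 50 uM (on this read-out higher numbers stand for more inhibition of growth at the one concentration tested and lower numbers for less inhibition of growth), compound 1 (`CC[C@](C)(CCCC(C)C)CCc1ccc(O)cc1`) gives 42%. Compound 2 (`COc1ccccc1/C=C/[C@@](C)(/C=C/c1ccc(O)cc1)CCC=C(C)C`) gives 50%, and the two values lie within the scatter of each other. Compound 3 (`COc1ccc(/C=C/[C@@](C)(/C=C/c2ccc(O)cc2)CCC=C(C)C)cc1`) has 4-methoxyphenyl in place of 2-methoxyphenyl on a double-bonded chain carbon bound to a double-bonded chain carbon. Among the compounds with values here, no measured pair tests this change, so the data give no direction for it. The expected shift in this assay is a number 2 percentage points higher from compound 2 to compound 3 (within the scatter), which is nothing beyond the scatter. For compound 3 the estimated value is 52%, within an expected range of 37% to 67%.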

Compound 3, percent growth inhibition at one concentration: 20%
Estimate against measurement, compound 3: 32 percentage points above; the whole stated range lies above it.
By their numbers in this assay, from the lowest: compound 3; then compounds 1 and 2 (each within the scatter of the next).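

In this assay the swap to 4-methoxyphenyl in place of 2-methoxyphenyl on a double-bonded chain carbon bound to a double-bonded chain carbon gives a number 30 percentage points lower from compound 2 to compound 3 (beyond the scatter) and so marks this position as sensitive. The two compounds have the same atoms, joined differently, so the arrangement of the methoxyphenyl alone moves this read-out, which the comparison of compound 1 and compound 2 could not show. Nothing at hand accounts for the loss.

As far as these compounds go, how a plain phenyl, or a phenyl carrying an amine in place of the methoxy group, would read at this place remains open. From the compounds shown here alone, whether the same swap would act alike on the core of compound 1 also remains open.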